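This account rests on a few compounds, and the source may have more. Where it says the series, first, only, none or still open, it means among the compounds named here.

Three compounds share one core and differ only in the group carried on the hydrazone arm. In an assay on CHO-K1 cells for displacement of a labelled ligand from adenosine receptor A1 (Homo sapiens), read by scintillation counting, with a stated time of 60 min (on this read-out higher numbers stand for weaker inhibition and lower numbers for stronger inhibition), compound 1 `Nc1nc(N/N=C/c2ccc(OCc3ccc(F)cc3)cc2)nc2c1ncn2[C@@H]1O[C@H](CO)[C@@H](O)[C@H]1O` gives 70 nM. Compound 2 `N#Cc1ccccc1/C=N/Nc1nc(N)c2ncn([C@@H]3O[C@H](CO)[C@@H](O)[C@H]3O)c2n1` gives 2.9 nM in this assay, and compound 3 `N#Cc1ccc(/C=N/Nc2nc(N)c3ncn([C@@H]4O[C@H](CO)[C@@H](O)[C@H]4O)c3n2)cc1` gives 4.1 nM, which places compound 3 second of the three numbers. The two measured steps read a 17-fold lower number from compound 1 to compound 3 (1.23 log units; beyond the scatter) and a 1.4-fold higher number from compound 2 to compound 3 (0.15 log units; within the scatter). Compound 4 `Nc1nc(N/N=C/c2ccc(C(F)(F)F)cc2)nc2c1ncn2[C@@H]1O[C@H](CO)[C@@H](O)[C@H]1O` carries trifluoromethyl in place of cyano on an aromatic carbon. For the measured compounds named here, no measured step exchanges cyano for trifluoromethyl, so the only guide is the large step at this same aromatic carbon, where a large group gave way to cyano. A smaller step in the weaker direction is expected here, about a 2.4-fold higher number from compound 3 to compound 4 (0.39 log units; beyond the scatter). Compound 4 is therefore estimated at 10 nM, with a range from 3 nM to 35 nM.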

Compound 4, inhibition constant: 37 nM
Estimate against measurement, compound 4: 3.7-fold (0.57 log units) below, outside the stated range (above it).
By their numbers in this assay, from the lowest: compounds 2 and 3 (each within the scatter of the next); then compounds 4 and 1 (each within the scatter of the next).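

For the compounds shown here, on this aromatic carbon, the exchange of cyano for trifluoromethyl costs far more than the earlier compounds suggested in this assay, with a 9.0-fold higher number from compound 3 to compound 4 (0.96 log units; beyond the scatter), and compound 4 also lies well away from the other nitrile, with a 13-fold higher number from compound 2 to compound 4 (1.11 log units; beyond the scatter). Trifluoromethyl and (4-fluorobenzyl)oxy cannot be told apart here, with a 1.9-fold lower number from compound 1 to compound 4 (0.28 log units; within the scatter), so among these compounds only the two nitriles, compound 2 and compound 3, stand apart. Nothing available explains this gap.

On these data alone, it remains open what an amine, a carboxylic acid or a plain methyl group on this carbon would give. Whether cyano is unusual here, or trifluoromethyl and (4-fluorobenzyl)oxy are the exceptions, therefore stays unsettled.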